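Replacing the 1-methyl-1H-pyrazol-4-yl group of compound 1

The source may report more compounds than this note shows. Statements on the series, on what has been measured and on what is new or still open speak of the compounds shown alone.

Compound 1 `COc1c([C@H](C)Nc2ncnc3[nH]cnc23)cc(Cl)c(C)c1-c1cnn(C)c1`: 950 nM
Compound 2 `CC(Nc1ncnc2[nH]cnc12)c1ccc2cccnc2c1-c1cccc(F)c1`: 3200 nM

Both values were measured in a functional assay on Pfeiffer cells (Homo sapiens) for cytotoxicity, read by scintillation counting and thymidine incorporation, with a stated time of 4 days; a higher number here means a weaker inhibitor, a lower number a stronger inhibitor. Compound 1 holds the lower number of the two, and compound 2, at 3200 nM, lies above it by more than the usual scatter.

Compound 3 `COc1c([C@H](C)Nc2ncnc3[nH]cnc23)cc(Cl)c(C)c1-c1cncc(S(C)(=O)=O)c1` keeps the core of compound 1 and changes one group. It carries 5-(methylsulfonyl)pyridin-3-yl in place of 1-methyl-1H-pyrazol-4-yl on an aromatic carbon, ortho to a methoxy group and ortho to a methyl group (5-(methylsulfonyl)pyridin-3-yl in place of 1-methyl-1H-pyrazol-4-yl on an aromatic carbon).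

Going by the values given here, no two measured compounds differ in one place only, so no measured step shows what a change at this place does in this assay. With nothing to set a direction, the expectation stays close to compound 1 at 950 nM, with no step beyond the scatter. The expected step is a 1.2-fold lower number from compound 1 to compound 3 (0.07 log units; within the scatter). For compound 3 the estimated value is 800 nM, with an expected range from 180 nM to 3500 nM.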

Compound 3, half-maximal inhibitory concentration: 40 nM
Compound 3: middle estimate off by 20-fold (1.30 log units), on the high side; the measured number lies below the stated range.
By their numbers in this assay, from the lowest: compound 3; then compound 1; then compound 2.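

Going by these compounds alone, with the 5-(methylsulfonyl)pyridin-3-yl group, this series gains its only single-place step in this assay, a 24-fold lower number from compound 1 to compound 3 (1.38 log units; beyond the scatter), and it is large. It shows that the group on this aromatic carbon, ortho to a methoxy group and ortho to a methyl group, strongly affects the number, and that for this pair a larger group with a six-membered aromatic ring goes with a lower number than the 1-methyl-1H-pyrazol-4-yl group. No measurement available here accounts for the size of this step.

The change replaces the ring and adds the methylsulfonyl group at once, so the compounds shown leave open which of the two carries the step, a question that a plain pyridin-3-yl or a 3-(methylsulfonyl)phenyl group at this place would address. On these data alone, compound 2 differs from compound 1 and compound 3 in more than one place, so its steps to them cannot be read, and whether the gain would hold on another core stays open.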